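This account rests on a few compounds, and the source may have more. Where it says the series, first, only, none or still open, it means among the compounds named here.

Working notes on the series.

Compound 1 `Cc1nc(C(NC(=O)C(=O)Nc2ccc(F)cc2F)C2CCCCN2)sc1CCO` is the reference point here. In an ADME assay on TZM-b1 cells (Homo sapiens) for cytotoxicity, read by XTT assay, with a stated time of 3 days (a lower number here means that less compound is tolerated, a higher number that more compound is tolerated), compound 1 gives > 84000 nM, which is a limit of the assay and not a number. That reading is the limit of > 84000 nM in this assay, at which 1 of the 3 values shown sits. Compound 2 `Cc1nc(C(NC(=O)C(=O)Nc2ccc(C(F)(F)F)cc2)C2CCCCN2)sc1CO` is likewise held at a limit: in this assay compound 2 gives > 75500 nM, again a limit and not a number, corresponding to the limit of > 75500 nM in this assay, at which 1 of the 3 values shown sits. Compound 3 `Cc1nc(C(NC(=O)C(=O)Nc2ccc(Cl)cc2)C2CCNCC2)sc1CO` is the only one of the three with a number, giving 81000 nM in this assay. For the measured compounds named here, no pair among compounds 1, 2 and 3 differs in a single place, so no measured step exists between them; all three readings stand at the high end of what this assay reports.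

Compound 4 `Cc1nc(C(NC(=O)C(=O)NC2CCCCCC2)C2CCCCN2)sc1CCO` is not yet measured. It differs from compound 1 by cycloheptyl in place of 2,4-difluorophenyl on an amide-type nitrogen. Since compound 1 stands only at a limit, the step in this assay is expected to be an at least 1.0-fold lower number from compound 1 to compound 4 (0.02 log units; that floor lies within the scatter), that is, nothing beyond the usual scatter. Compound 4 is accordingly estimated at 80000 nM in this assay, with a range from 40000 nM to 160000 nM, and with a fair chance that only a limit is reported again.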

Compound 4, half-maximal cytotoxic concentration: > 88000 nM
Compound 4: a limit, no number (the forecaster's own chance of this, stated with the estimate: 70%); middle value at least 1.1-fold (0.04 log units) from the limit.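

Compound 4 gives > 88000 nM in this assay, a limit of the assay and not a number. For the compounds shown here, compound 1 also stands only at a limit, so no step between compound 1 and compound 4 can be read. The compounds shown leave open the actual half-maximal cytotoxic concentration of either compound.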